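Ester for Hydroxymethyl at the Aryl Terminus

A few compounds are considered here, and "the series" means these few. Any claim that something is new, unique, unknown or untested is made for them only; others in the source may bear on it.

The series rests on one shared core, carried unchanged from compound 1 `COc1ccc(C(=O)Nc2ccc(-c3ccc(C=O)cc3C)cc2)cc1CCCN(C)C` to compound 2 `COc1ccc(C(=O)Nc2ccc(-c3ccc(CO)cc3C)cc2)cc1CCCN(C)C`. In a functional assay for agonist activity at 5-hydroxytryptamine receptor 1D (Cavia porcellus) (a lower number here means that less compound is needed, a higher number that more compound is needed for the effect), compound 1 gives 45 mg/kg, and in this assay compound 2 gives 45 mg/kg, so compound 2 stands level with compound 1 at the digits recorded. Within the data shown here, the only step measured so far, no change at the digits printed from compound 1 to compound 2 (within the scatter), is the replacement of a formyl group by a hydroxymethyl group on the same aromatic carbon.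

Compound 3 `COCCOC(=O)c1ccc(-c2ccc(NC(=O)c3ccc(OC)c(CCCN(C)C)c3)cc2)c(C)c1` takes the next step from compound 2: (2-methoxyethoxy)carbonyl in place of hydroxymethyl on an aromatic carbon. Among the measured compounds shown here, only the step from compound 1 to compound 2 bears on this position, and it was flat within the scatter, while the present change is larger, with more atoms entering and the donor leaving. On these numbers compound 3 is expected to show a step of a 1.1-fold higher number from compound 2 to compound 3 (0.05 log units; within the scatter) in this assay, that is, no movement beyond the scatter, with the uncertainty widened by the size of the change. The estimate for compound 3 in this assay is therefore 50 mg/kg, within a range from 20 mg/kg to 130 mg/kg.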

Compound 3, dose for half-maximal effect: 45 mg/kg
Compound 3: middle estimate off by 1.1-fold (0.05 log units), on the high side; low and high end bracket the measured number.
By their numbers in this assay, from the lowest: compounds 1, 2 and 3 (each within the scatter of the next).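

The ester extends the flat reading at this position to a much larger group: with (2-methoxyethoxy)carbonyl in place of hydroxymethyl, this assay shows no change at the digits printed from compound 2 to compound 3 (within the scatter) even though 7 heavy atoms enter where 2 leave. Measured against the aldehyde, 2-methoxyethoxy in place of hydrogen on the carbonyl carbon likewise gives no change at the digits printed from compound 1 to compound 3 (within the scatter) and so ties all three compounds together at one reading. Compound 2 carries a hydrogen-bond donor here and compound 3 carries none, yet the two read alike in this assay, although nothing available explains that outcome.

Whether this tolerance extends further remains open, as the compounds shown say nothing about a carboxylic acid, an aminomethyl group or a longer chain ending in an amine at this aromatic carbon. With every reading at a single level, they also do not show which group at this position, if any, would shift the dose needed in either direction, or whether changes elsewhere on the shared core would behave the same way.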